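A few compounds are considered here, and "the series" means these few. Any claim that something is new, unique, unknown or untested is made for them only; others in the source may bear on it.

Compound 1 `CCOC(=O)CCCCCOc1cccc(CN(C(=O)c2ccc(-c3ccncc3)cc2)C(C)C)c1` and compound 2 `CCOC(=O)CCCCCOc1cccc(CN(C(=O)c2ccc(-c3ccoc3)cc2)C(C)C)c1` share one core and differ only in the ring attached to it. In an ADME assay on BJ cells (Homo sapiens) for cytotoxicity, read by CellTiter-Glo and resazurin assay, with a stated time of 72 h (on this read-out lower numbers stand for an effect already at smaller amounts and higher numbers for an effect only at larger amounts of compound), compound 1 gives only a limit, > 26000 nM. In this assay compound 2 likewise gives only a limit, > 26000 nM. The step that the two limits leave unreadable from compound 1 to compound 2 therefore cannot be read, since (the limit of > 26000 nM in this assay, at which 2 of the 2 values shown sit). Going by the values given here, compound 2 thus stands at that limit, the same limit at which the one further value shown stands. Compound 3 `CCOC(=O)CCCCCOc1cccc(CN(C(=O)c2ccc(-c3cccc(OC(C)C)c3)cc2)C(C)C)c1` differs from compound 2 by 3-isopropoxyphenyl in place of furan-3-yl on an aromatic carbon. Among the compounds with values here, the single measured step bears on this change only by showing that both earlier rings leave the read-out at the limit; it gives neither a size nor a direction, so no step beyond the scatter is expected in this assay, and a further limit is the most likely outcome. Compound 3 is therefore estimated at 30000 nM, with a range from 15000 nM to 80000 nM. The step that the limit leaves unreadable from compound 2 to compound 3 that this estimate means is expected to stay within the scatter.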

Compound 3, half-maximal effective concentration: > 26000 nM
Compound 3 ended at the assay's limit (the forecaster's own chance of this, stated with the estimate: 80%); the middle value is on the limit's open side.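

No step between compound 1, compound 2 and compound 3 can be read in this assay, since each gives only a limit: the limit of > 26000 nM in this assay, at which 3 of the 3 values shown sit.

The compounds shown leave open whether pyridin-4-yl, furan-3-yl and 3-isopropoxyphenyl differ at all in this read-out.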